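A few compounds are considered here, and "the series" means these few. Any claim that something is new, unique, unknown or untested is made for them only; others in the source may bear on it.

Measured in a functional assay on T29Kt1 cells (Homo sapiens) for cytotoxicity, read by sulforhodamine B assay, with a stated time of 3 days (on this read-out higher numbers stand for weaker inhibition and lower numbers for stronger inhibition), so far
compound 1 `OCc1cn(Cc2cccc(F)c2)c2ccccc12` gives 20 nM
compound 2 `OCc1cn(Cc2cccc(Cl)c2)c2ccccc12` gives 160 nM
compound 3 `OCc1cn(Cc2cccc(C(F)(F)F)c2)c2ccccc12` gives 560 nM

Compound 1 holds the lowest number of the three in this assay and is the strongest inhibitor so far. Compound 4 `OCc1cn(Cc2cccc(F)c2)c2ccc(Cl)cc12` keeps the core of compound 1 and differs by chloro in place of hydrogen on an aromatic carbon, with chloro in place of hydrogen on an aromatic carbon. For the measured compounds named here, no measured step makes this change. The closest evidence is indirect and comes from a different place in the structure, where both replacements of fluoro raised the number: an 8.0-fold higher number from compound 1 to compound 2 (0.90 log units; beyond the scatter) and a 28-fold higher number from compound 1 to compound 3 (1.45 log units; beyond the scatter). A modest move towards a higher number is therefore expected, as an estimated 3.0-fold higher number from compound 1 to compound 4 (0.48 log units; beyond the scatter) overall. Compound 4 is estimated at 60 nM, with an expected range of 12 nM to 300 nM overall.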

Compound 4, half-maximal inhibitory concentration: 160 nM
Compound 4: middle estimate off by 2.7-fold (0.43 log units), on the low side; measured number inside the range.
By their numbers in this assay, from the lowest: compound 1; then compounds 2 and 4 (each within the scatter of the next); then compound 3.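

In this assay, chloro in place of hydrogen on an aromatic carbon of the fused system gives an 8.0-fold higher number from compound 1 to compound 4 (0.90 log units; beyond the scatter). For the compounds shown here, the earlier steps changed only the group at the fluoro site of compound 1, so this is the first sign that the number also responds to a change elsewhere on the core, with hydrogen giving the lower number of the two groups compared here. Nothing available explains this rise. As far as these compounds go, it remains open how this position responds to groups other than chloro, such as methoxy or an amine.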